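The source may report more compounds than this note shows. Statements on the series, on what has been measured and on what is new or still open speak of the compounds shown alone.

Measured so far:
compound 1 `COc1cc(Cc2nc3c(N)ncnc3n2CCCO)cc(OC)c1OC` — 92700000 nM
compound 2 `CCCCCn1c(Cc2cc(OC)c(OC)c(OC)c2)nc2c(N)nc(F)nc21` — 286000000 nM

Among the measured compounds shown here, in a functional assay on MCF7 cells (Homo sapiens) for cytotoxicity (on this read-out higher numbers stand for an effect only at larger amounts of compound and lower numbers for an effect already at smaller amounts), compound 2 gives 286000000 nM, the higher of the two numbers so far. Its nearest neighbour is compound 1, and in this assay compound 1 gives 92700000 nM; the gap between these two values lies beyond the scatter, so compound 2 acts only at the larger amount of the pair. Both numbers are very large, and the series shows an effect only at very high amounts of compound.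

Compound 3 `COCCCn1c(Cc2cc(OC)c(OC)c(OC)c2)nc2c(N)nc(F)nc21` differs from compound 2 in one place: methoxy in place of ethyl on a saturated chain carbon, three bonds along the chain from an aromatic nitrogen. For the measured compounds named here, no pair of measured compounds covers this change, so nothing measured sets the size of the step. The expectation is that compound 3 stays near compound 2, with at most a modest move toward a lower number, a step from compound 2 to compound 3 of a 1.9-fold lower number from compound 2 to compound 3 (0.28 log units; within the scatter) being expected. For compound 3 the estimated value in this assay is 150000000 nM, with a range from 50000000 nM to 450000000 nM.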

Compound 3, half-maximal effective concentration: 72600000 nM
Compound 3: middle estimate off by 2.1-fold (0.32 log units), on the high side, and the stated range covers the measured number.
By their numbers in this assay, from the lowest: compounds 3 and 1 (each within the scatter of the next); then compound 2.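

Among the compounds shown here, this is the first step read at this place: in this assay, methoxy in place of ethyl on a saturated chain carbon, three bonds along the chain from an aromatic nitrogen, moves the read-out beyond the scatter (a 3.9-fold lower number from compound 2 to compound 3 (0.60 log units; beyond the scatter)). The two groups count the same 2 heavy atoms, so a change that swaps one carbon for one oxygen and adds 1 hydrogen-bond acceptor is enough to give a modest step, although the number for compound 3 remains very large. Nothing available accounts for this step.

From the compounds shown here alone, whether the step depends on the oxygen itself or on where it sits along the chain remains open. An amine or a carboxylic acid at the end of this chain on the same core would test whether other groups here move the number further.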